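Swapping the aryl group on a piperazine urea

The compounds below may be only part of what the source reports. "The series", "measured", "known", "first", "only" and "open" are said of these compounds alone.

Three compounds share a piperazine urea core and differ only in the aromatic group attached to the urea nitrogen. In an assay on isolated protein for inhibition of Fatty-acid amide hydrolase 1 (Rattus norvegicus), with a stated time of 60 min (a lower number here means a stronger inhibitor, a higher number a weaker inhibitor), compound 1 `O=C(Nc1cccc2nonc12)N1CCN(Cc2cccc(Oc3ccc(Cl)cc3)c2)CC1` gives 120 nM, compound 2 `O=C(Nc1cccc2cn[nH]c12)N1CCN(Cc2cccc(Oc3ccc(Cl)cc3)c2)CC1` gives 6000 nM, and compound 3 `O=C(Nc1cncc2ccccc12)N1CCN(Cc2cccc(Oc3ccc(Cl)cc3)c2)CC1` gives 8.3 nM, the lowest of the three numbers and therefore the strongest inhibitor here, with the move a 14-fold lower number from compound 1 to compound 3 (1.16 log units; beyond the scatter) and the move a 720-fold lower number from compound 2 to compound 3 (2.86 log units; beyond the scatter) both far beyond the scatter. Compound 4 `O=C(Nc1noc2ccccc12)N1CCN(Cc2cccc(Oc3ccc(Cl)cc3)c2)CC1` has not yet been measured in this assay. Going from compound 3 to compound 4 means (a group of 9 heavy atoms (7 carbon, 1 nitrogen, 1 oxygen; one five-membered aromatic ring with 2 hetero atoms, one six-membered aromatic ring of carbon only) in place of a group of 10 heavy atoms (9 carbon, 1 nitrogen; one six-membered aromatic ring of carbon only, one six-membered aromatic ring with 1 hetero atom), on an amide-type nitrogen). The two measured steps that bear on it are the reverse of those just described: both earlier changes from a fused five-membered ring to the six-membered ring of compound 3 brought large drops in the number, so returning to a fused five-membered ring is expected to raise it again. The step of an 18-fold higher number from compound 3 to compound 4 (1.26 log units; beyond the scatter) is expected to be large, and compound 4 is estimated at 150 nM, within a range of 30 nM to 800 nM.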

Compound 4, half-maximal inhibitory concentration: 8.1 nM
Compound 4: middle estimate off by 19-fold (1.27 log units), on the high side; the measured number lies below the stated range.
By their numbers in this assay, from the lowest: compounds 4 and 3 (each within the scatter of the next); then compound 1; then compound 2.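

In this assay a group with a five-membered aromatic ring can match isoquinolin-4-yl, with a 1.0-fold lower number from compound 3 to compound 4 (0.01 log units; within the scatter) lying within the scatter. Ring size alone therefore does not set the number at this amide-type nitrogen: a 740-fold lower number from compound 2 to compound 4 (2.87 log units; beyond the scatter) and a 15-fold lower number from compound 1 to compound 4 (1.17 log units; beyond the scatter) are both large, even though each of these changes swaps one fused group of 9 heavy atoms for another and keeps a five-membered ring. Nothing available here explains why these closely related groups differ so widely.

Going by these compounds, it remains open whether a plain phenyl group on the same nitrogen would give a number like those of compound 3 and compound 4. On these data alone, it is also open whether their match would hold if the chlorine elsewhere in the molecule gave way to a carboxylic acid.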